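Swapping the trimethoxyphenyl ketone for a tolyl ketone

A few compounds are considered here, and "the series" means these few. Any claim that something is new, unique, unknown or untested is made for them only; others in the source may bear on it.

Among the measured compounds shown here, compound 2 `COc1ccc(-c2cc(/C=C/C(=O)c3cc(OC)c(OC)c(OC)c3)nc3cc(-c4ccccc4)nn23)cc1OC` stands lowest of the three numbers measured so far: in a functional assay on DU-145 cells (Homo sapiens) for antiproliferative activity, read by MTT assay, with a stated time of 24 h (on this read-out higher numbers stand for weaker inhibition and lower numbers for stronger inhibition), compound 2 gives 8300 nM. Its nearest neighbour is compound 3 `COc1ccc(-c2cc(C(=O)/C=C/c3ccc(C)cc3)nc3cc(-c4ccccc4)nn23)cc1OC`, which in this assay gives 19500 nM, and the furthest is compound 1 `COc1cc(C(=O)/C=C/c2cc(-c3cc(OC)c(OC)c(OC)c3)n3nc(-c4ccccc4)cc3n2)cc(OC)c1OC`, which gives 34900 nM. For the measured compounds named here, the only single-change step measured, a 4.2-fold lower number from compound 1 to compound 2 (0.62 log units; beyond the scatter), came from a hydrogen in place of a methoxy on an aromatic carbon. Compound 4 `COc1ccc(-c2cc(/C=C/C(=O)c3ccc(C)cc3)nc3cc(-c4ccccc4)nn23)cc1OC` differs from compound 2 by 4-methylphenyl in place of 3,4,5-trimethoxyphenyl on a carbonyl carbon, the change sitting on a carbonyl carbon whose other neighbour is a double-bonded chain carbon. Going by the values given here, no measured step matches this change directly. Compound 3 also carries a 4-methylphenyl, and its value of 19500 nM sits above that of compound 2, while compound 1 at 34900 nM shows that methoxy count matters in this assay, so a weakening is expected. Compound 4 is therefore expected to give a higher number, a 2.4-fold higher number from compound 2 to compound 4 (0.38 log units; beyond the scatter), estimated at 20000 nM with a range from 6000 nM to 70000 nM.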

Compound 4, half-maximal inhibitory concentration: 26800 nM
Compound 4: middle estimate off by 1.3-fold (0.13 log units), on the low side, within the range that was stated.
By their numbers in this assay, from the lowest: compound 2; then compounds 3, 4 and 1 (each within the scatter of the next).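

On a carbonyl carbon whose other neighbour is a double-bonded chain carbon, 4-methylphenyl in place of 3,4,5-trimethoxyphenyl gives a 3.2-fold higher number from compound 2 to compound 4 (0.51 log units; beyond the scatter) in this assay. This shows that the aryl group on the ketone side also moves the number, whereas the earlier step concerned only a methoxy on an aromatic carbon of the other aryl group. The exchange of (2-(4-methylphenyl)ethenyl)carbonyl for 2-((4-methylphenyl)carbonyl)ethenyl gives a 1.4-fold higher number from compound 3 to compound 4 (0.14 log units; within the scatter), so with 4-methylphenyl in place, the two arrangements of the chain cannot be told apart here. No measured evidence accounts for either step.

The compounds shown leave open how a 4-methoxyphenyl or a 4-aminophenyl on that carbonyl carbon would compare. Also open, as far as these compounds go, is whether the two chain arrangements would still match with 3,4,5-trimethoxyphenyl in place of 4-methylphenyl.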